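Swapping the Aryl Group and Watching Solubility

This account rests on a few compounds, and the source may have more. Where it says the series, first, only, none or still open, it means among the compounds named here.

Compound 1 `CCOC(=O)c1c(-c2cccc(F)c2)[nH]c2cc(OC)ccc2c1=O` was measured in a physicochemical assay for solubility, in phosphate buffer, at pH 7.4 (on this read-out higher numbers stand for higher solubility and lower numbers for lower solubility), where compound 1 gives > 100000 nM, a limit of the assay rather than a number. Compound 2 `CCOC(=O)c1c(-c2ccccc2Cl)[nH]c2cccc(OC)c2c1=O` is also known in this assay; compound 2 gives > 100000 nM, again only a limit. Both shown values thus sit at the limit of > 100000 nM in this assay, at which 2 of the 2 values shown sit, and no step between measured compounds is available, so where compound 1 stands is known only as this limit. Compound 3 `CCOC(=O)c1c(-c2ccc(OC)cc2)[nH]c2cc(OC)ccc2c1=O` has not yet been measured in this assay. It differs from compound 1 in one place: 4-methoxyphenyl in place of 3-fluorophenyl on an aromatic carbon. With both shown values resting at the same limit, no step beyond the usual scatter can be inferred in either direction, and a result at the limit once more is the plain expectation. Compound 3 is expected to give 100000 nM, within a range of 40000 nM to 250000 nM. The expected step is a number no higher from compound 1 to compound 3 (the limit leaves the size open), which stays within the scatter.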

Compound 3, solubility: 8000 nM
Compound 3: middle estimate off by 13-fold (1.10 log units), on the high side; measured number below the stated range.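

Putting 4-methoxyphenyl in place of 3-fluorophenyl on the aromatic carbon next to the ring nitrogen gives an at least 12-fold lower number from compound 1 to compound 3 (1.09 log units; beyond the scatter) in this assay. Compound 3, at 8000 nM, supplies the first value here that is a number rather than a limit, so the exchange of aryl groups at this position is shown to matter in this read-out, which the earlier compounds could not show. The step is still a minimum, since its starting value is a limit, as are most values shown: the limit of > 100000 nM in this assay, at which 2 of the 3 values shown sit.

The step changes both the substituent and its place on the phenyl ring, and the compounds shown do not separate the two. On these data alone, whether 3-methoxyphenyl, 4-fluorophenyl or a phenyl carrying a carboxylic acid at this position would give a number or a limit remains open.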